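The compounds below may be only part of what the source reports. "The series", "measured", "known", "first", "only" and "open" are said of these compounds alone.

Working notes on the series.

In a functional assay on MIA PaCa-2 cells (Homo sapiens) for cytotoxicity, read by MTT assay, with a stated time of 72 h, tested at 10 uM (on this read-out lower numbers stand for a stronger effect and higher numbers for a weaker effect at the one concentration tested), three compounds have been measured. Compound 1, `C/C=C1\C(=O)O[C@@H](c2ccc([N+](=O)[O-])cc2)[C@H]1C`, gives 110%. Compound 2, `C=C1C(=O)O[C@@H](c2ccccc2)[C@H]1c1ccccc1`, gives 3%. Compound 3, `C=C1C(=O)O[C@H](c2ccccc2)[C@H]1c1ccccc1`, gives 1%, the lowest of the three numbers; its nearest neighbour is compound 2, and the gap to compound 1 is far beyond the scatter. Among the compounds with values here, the one measured single-point step is a number 2 percentage points lower from compound 2 to compound 3 (within the scatter), which rests on the fact that compounds 2 and 3 differ only in the configuration as drawn: the two compounds differ only in the configuration as drawn, and the read-out does not move beyond the scatter.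

The next compound, compound 4, `C=C1C(=O)O[C@H](c2ccc(C)cc2)[C@H]1c1ccccc1`, differs from compound 3 by methyl in place of hydrogen on an aromatic carbon. Within the data shown here, no measured step in this set changes a substituent on an aromatic ring, so the expectation rests on the level of compound 3, 1%, and the measured step within the scatter. A methyl in place of hydrogen is expected to leave the read-out near where compound 3 stands, with a number 2 percentage points higher from compound 3 to compound 4 (within the scatter) expected to stay within the scatter. Compound 4 is therefore estimated at 3%, between 0% and 20%.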

Compound 4, a percentage reported as activity, at one concentration (the size of the read-out at that concentration, not a potency): 2%
Beside the measured number, compound 4's estimate is 1 percentage points above it; measured number inside the range.
By their numbers in this assay, from the lowest: compounds 3, 4 and 2 (each within the scatter of the next); then compound 1.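

In this assay, a number 1 percentage points higher from compound 3 to compound 4 (within the scatter), so methyl in place of hydrogen on an aromatic carbon, para to a large group, does not move the read-out beyond the scatter. Within the data shown here, the earlier step changed configuration only, whereas this is the first measured change of a substituent on an aromatic ring, and it shows that this position accepts a methyl without a loss of effect beyond the scatter. Nothing available explains why the read-out holds at this position.

As far as these compounds go, whether an amine, a carboxylic acid or a longer chain at the same position would hold the read-out stays open, as does the same methyl change on the other aromatic ring. A read-out at one concentration also leaves open whether compounds 2, 3 and 4 would separate at lower concentrations.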